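The compounds below may be only part of what the source reports. "The series", "measured", "known", "first", "only" and "open" are said of these compounds alone.

Three compounds have been measured in the same test:
compound 1, `Cc1ccc(C23CCC(=O)N2CCCO3)c(C)c1`, gives 150 mg/kg;
compound 2, `O=C(CCC(=O)c1ccc(F)cc1)NCCCO`, gives 500 mg/kg;
compound 3, `O=C1CCCC2(c3ccccc3)OCCCN12`, gives 150 mg/kg.

All three numbers come from a functional assay on the whole organism (Central nervous system) with Mus musculus as the target; on this read-out higher numbers stand for an effect only at larger amounts of compound and lower numbers for an effect already at smaller amounts. Compound 2 holds the highest of the three numbers: compound 1 and compound 3 both lie below it by a gap that is beyond the usual scatter, so compound 2 acts only at larger amounts than either of the other two.

Compound 4, `Cc1ccc(C(=O)CCC(=O)NCCCO)cc1`, has not yet been measured. It differs from compound 2 in one place: methyl in place of fluoro on an aromatic carbon. Within the data shown here, no measured pair shows this same exchange, so there is no direct guide to its effect. A methyl on an aromatic ring appears only in compound 1, and that compound differs from compound 2 in many other places at once, so its number says little about this one change. The expected step from compound 2 to compound 4 in this assay is therefore small and likely within the usual scatter, a 1.3-fold lower number from compound 2 to compound 4 (0.10 log units; within the scatter). For compound 4 the estimated value in this assay is 400 mg/kg, with a likely range from 150 mg/kg to 1000 mg/kg.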

Compound 4, dose for half-maximal effect: 700 mg/kg
Compound 4: the middle estimate sits 1.8-fold (0.24 log units) below what was measured; measured number inside the range.
By their numbers in this assay, from the lowest: compounds 1 and 3 (each within the scatter of the next); then compounds 2 and 4 (each within the scatter of the next).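

In this assay, methyl in place of fluoro on the aromatic carbon para to a large group gives a 1.4-fold higher number from compound 2 to compound 4 (0.15 log units; within the scatter). Among these compounds, this is the first direct reading of this exchange, and it shows that these two groups, each of a single heavy atom and neither carrying a hydrogen-bond donor or acceptor, cannot be told apart at this position in this test. No measurement available here speaks to the reason for this result.

From the compounds shown here alone, only fluoro and methyl have been compared at this position, so it remains open whether a group such as an amine or a carboxylic acid would leave the number within the scatter too. Going by these compounds, it is also open whether the same exchange would give a similar result on the core of compound 3.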